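Ester-to-acid change on the shared core

The source may report more compounds than this note shows. Statements on the series, on what has been measured and on what is new or still open speak of the compounds shown alone.

Measured so far in an assay on CHO cells for displacement of a labelled ligand from adenosine receptor A1 (Homo sapiens); on this read-out higher numbers stand for weaker inhibition and lower numbers for stronger inhibition:
compound 1 `CCOC(=O)c1cnc(NCc2ccc(F)cc2)n2nc(-c3ccco3)nc12`: 932 nM
compound 2 `CCOC(=O)c1cnc(NCCOC)n2nc(-c3ccco3)nc12`: 2270 nM
compound 3 `CCOC(=O)c1cnc(N(C)C)n2nc(-c3ccco3)nc12`: 13400 nM

Compound 1 gives the lowest number of the three, with a 2.4-fold higher number from compound 1 to compound 2 (0.39 log units; beyond the scatter) and a 14-fold higher number from compound 1 to compound 3 (1.16 log units; beyond the scatter) both beyond the scatter. All three measured steps concern the amine substituent on the aromatic carbon; the ester stays fixed throughout.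

Compound 4 `O=C(O)c1cnc(NCc2ccc(F)cc2)n2nc(-c3ccco3)nc12` differs from compound 1 by hydrogen in place of ethyl on an oxygen next to a carbonyl group. Going by the values given here, no measured step touches this position, so no step bears directly on it; the expectation rests on the unchanged remainder of the core. For compound 4 a step of a 5.4-fold higher number from compound 1 to compound 4 (0.73 log units; beyond the scatter) is expected, toward a higher number, with wide uncertainty. Compound 4 is therefore estimated at 5000 nM, within 1000 nM to 30000 nM.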

Compound 4, inhibition constant: > 100000 nM
Compound 4 ended at the assay's limit; the forecaster's own chance of this, stated with the estimate: 10%; middle value at least 20-fold (1.30 log units) away from the limit.
By their numbers in this assay, from the lowest: compound 1; then compound 2; then compound 3. At a limit, above all of these: compound 4.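

The ester position, fixed in all earlier compounds, proves far more sensitive in this assay than the amine substituent: hydrogen in place of ethyl gives an at least 100-fold higher number from compound 1 to compound 4 (2.03 log units; beyond the scatter). The change from ethoxycarbonyl to carboxy therefore outweighs every measured amine change on the shared core. Compound 4 stands at a limit of the assay, not at a number: the limit of > 100000 nM in this assay, at which 1 of the 4 values shown sits.

Going by these compounds, whether a methyl ester or a primary amide at this position stays close to compound 1 remains open. Also open, on these data alone, is whether carboxy has the same effect alongside the (2-methoxyethyl)amino or dimethylamino groups.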